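Cyclopropyl for methyl on the carbonyl of compound 2

A few compounds are considered here, and "the series" means these few. Any claim that something is new, unique, unknown or untested is made for them only; others in the source may bear on it.

Compound 1, `CC1=C(C(=O)C2CC2)C(c2ccco2)NC(=O)N1`, in an assay on membranes from CHO cells for displacement of a labelled ligand from adenosine receptor A1 (Homo sapiens), read by scintillation counting, with a stated time of 60 min, tested at 1 uM (a lower number here means less inhibition, a higher number more inhibition at the concentration tested (going by the name of the read-out)), gives 2%. Compound 2, `CC(=O)C1=C(C)NC(=O)NC1c1ccoc1`, in this assay gives 6%.

Compound 2 and compound 1 differ by an amount within the usual scatter, so neither stands apart; both show little inhibition. Compound 3, `CC1=C(C(=O)C2CC2)C(c2ccoc2)NC(=O)N1`, carries cyclopropyl in place of methyl on a carbonyl carbon. Going by the values given here, no measured pair shows this change alone, so its effect is unknown here. Given that compound 1 also gives 2% with the same cyclopropylcarbonyl group, the step of a number 1 percentage points lower from compound 2 to compound 3 (within the scatter) is expected to stay within the scatter. Compound 3 is estimated at 5%, between -5% and 15%.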

Compound 3, a percentage reported as inhibition, at one concentration (the size of the read-out at that concentration, not a potency): 1%
For compound 3 the middle estimate is 4 percentage points above the measured one, and the stated range covers the measured number.
By their numbers in this assay, from the lowest: compounds 3, 1 and 2 (each within the scatter of the next).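

In this assay, the change from methyl to cyclopropyl on a carbonyl carbon now has a measured pair, and acetyl to cyclopropylcarbonyl stays within the scatter (a number 5 percentage points lower from compound 2 to compound 3 (within the scatter)). With cyclopropylcarbonyl held constant, furan-3-yl in place of furan-2-yl on a saturated ring carbon also stays within the scatter (a number 1 percentage points lower from compound 1 to compound 3 (within the scatter)). No further data bear on this result.

All three compounds show little inhibition, so neither change has been seen in a compound with a larger read-out. As far as these compounds go, what a longer chain on the carbonyl carbon, or a phenyl in place of the furan-3-yl, would give remains open.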